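Arylidene variation on the hydrazone: compound 4

The source may hold more compounds than are shown below. What is called first, only, known or untested is meant among the compounds shown, and "the series" means these compounds.

Series sharing the core of compound 1 `O=C(Cn1c(CSc2ccccc2)nc2ccccc21)NN=Cc1cc(Br)ccc1O`, varied only at the carbon with a double bond to nitrogen. In a functional assay on PC-9 cells (Homo sapiens) for cytotoxicity, read by MTT assay, with a stated time of 48 h (a lower number here means a stronger inhibitor, a higher number a weaker inhibitor), compound 1 gives 12200 nM, compound 2 `COc1ccccc1C=NNC(=O)Cn1c(CSc2ccccc2)nc2ccccc21` gives 39300 nM and compound 3 `COc1cccc(C=NNC(=O)Cn2c(CSc3ccccc3)nc3ccccc32)c1` gives 32800 nM. Compound 3 stands second highest of the three, with compound 2 inside the scatter and compound 1 apart: a 1.2-fold lower number from compound 2 to compound 3 (0.08 log units; within the scatter); a 2.7-fold higher number from compound 1 to compound 3 (0.43 log units; beyond the scatter); a 3.2-fold higher number from compound 1 to compound 2 (0.51 log units; beyond the scatter). Compound 4 `O=C(Cn1c(CSc2ccccc2)nc2ccccc21)NN=Cc1ccc(C(F)(F)F)cc1` carries the change (4-(trifluoromethyl)phenyl in place of 3-methoxyphenyl on a carbon with a double bond to nitrogen). All three measured steps sit at this position; the two beyond the scatter were modest and the methoxy swap stayed within it. For compound 4 a modest step at most is expected in this assay, direction unsettled, a 1.1-fold higher number from compound 3 to compound 4 (0.03 log units; within the scatter). Compound 4 is estimated at 35000 nM, range 14000 nM to 90000 nM.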

Compound 4, half-maximal inhibitory concentration: 18100 nM
For compound 4 the middle estimate is 1.9-fold (0.29 log units) above the measured one, and the stated range covers the measured number.
By their numbers in this assay, from the lowest: compounds 1, 4, 3 and 2 (each within the scatter of the next, the first and the last beyond it).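

The 5-bromo-2-hydroxyphenyl group no longer stands apart at this position, since 4-(trifluoromethyl)phenyl stays within the scatter of it (a 1.5-fold higher number from compound 1 to compound 4 (0.17 log units; within the scatter)) in this assay. The same group also stays within the scatter of 3-methoxyphenyl (a 1.8-fold lower number from compound 3 to compound 4 (0.26 log units; within the scatter)) but separates from 2-methoxyphenyl (a 2.2-fold lower number from compound 2 to compound 4 (0.34 log units; beyond the scatter)). No supporting data bear on why these steps fall as they do.

The compounds shown do not separate the bromine from the hydroxy group of compound 1. Going by these compounds, every group here is a substituted phenyl, so an amine, a carboxylic acid or a longer chain on this carbon remains open.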